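The compounds below may be only part of what the source reports. "The series", "measured", "known", "first", "only" and "open" are said of these compounds alone.

Measured compounds in a functional assay on MDA-MB-231 cells (Homo sapiens) for cytotoxicity, read by sulforhodamine B assay, with a stated time of 48 h, tested at 0.1 uM; a lower number here means a stronger effect, a higher number a weaker effect of the compound at the concentration tested:

Compound 1, `COc1ccc(-c2cc(/C=C/C(=O)c3ccc(N)cc3)[nH]n2)cc1`, gives 89%.
Compound 2, `COc1ccc(C(=O)/C=C/c2cc(-c3cc(OC)c(OC)c(OC)c3)n[nH]2)cc1OC`, gives 101%.
Compound 3, `COc1ccc(-c2cc(/C=C/C(=O)c3ccc(N)cc3)[nH]n2)cc1OC`, gives 107%.

Compound 1 and compound 3 share a core and differ in one place: methoxy in place of hydrogen on an aromatic carbon. This change in this assay produced a step of a number 18 percentage points higher from compound 1 to compound 3 (beyond the scatter), so the methoxy group left the compound with a weaker effect at the tested concentration. Compound 2 carries a different core, and the difference between the core of compound 1 and that of compound 2 is not broken down here; the two values show that compound 2 sits above compound 1 and near compound 3.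

Compound 4, `COc1cc(C(=O)/C=C/c2cc(-c3cc(OC)c(OC)c(OC)c3)n[nH]2)cc(OC)c1OC`, is not yet measured. It arises from compound 2 by methoxy in place of hydrogen on an aromatic carbon. Within the data shown here, this is the same kind of change as the one from compound 1 to compound 3, but the surroundings are not identical: in compound 4 the entering methoxy is also meta to a methoxy group, which was not so in compound 3. Because the earlier step was a number 18 percentage points higher from compound 1 to compound 3 (beyond the scatter) and compound 2 already lies near the value that means almost no effect, the expected step for compound 4 is a number 2 percentage points higher from compound 2 to compound 4 (within the scatter), a small or no change rather than a repeat of the earlier rise. On that basis compound 4 is expected to give about 103% in this assay, with a plausible span from 92% to 114%.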

Compound 4, a percentage reported as activity, at one concentration (the size of the read-out at that concentration, not a potency): 104%
Beside the measured number, compound 4's estimate is 1 percentage points below it; low and high end bracket the measured number.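

In this assay, methoxy in place of hydrogen on an aromatic carbon, here entering ortho to a methoxy group and meta to a second one, gave a step of a number 3 percentage points higher from compound 2 to compound 4 (within the scatter). The same change therefore did not carry over from one core to the other with the same size of step: the same change on two cores in this assay, a number 18 percentage points higher (beyond the scatter) from compound 1 to compound 3 and a number 3 percentage points higher (within the scatter) from compound 2 to compound 4, 15 percentage points apart, beyond the scatter of two such steps What this does not show is which difference between the two cores or the surroundings of the entering methoxy accounts for that gap, and two pairs of compounds, each read at a single concentration, cannot say how the change would behave on a third core or what it does to potency.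

The compounds shown leave open how this series responds when something other than methoxy enters on the aromatic ring, such as a hydroxy group, a fluorine atom or a longer chain like ethoxy. Among these compounds, they also leave open whether the amine of compound 1 and compound 3 matters for the size of the step, since no pair here changes that group while the rest of the compound stays the same.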